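Deacetylation of the acetoxymethyl pyranone enone core

This account rests on a few compounds, and the source may have more. Where it says the series, first, only, none or still open, it means among the compounds named here.

Three esters of the shared core have been measured in a functional assay on LFCl2A cells (Rattus norvegicus) for cytotoxicity; a higher number here means a weaker inhibitor, a lower number a stronger inhibitor. Compound 1 `CC(=O)OC[C@H]1O[C@H](CC2=CCCCC2)C=CC1=O` gives 150 nM in this assay. Compound 3 `CCCCCCCC/C=C\CCCCCCCC(=O)OC[C@H]1O[C@H](C2CCCC=C2C)C=CC1=O` gives 50 nM, a lower number than compound 1, while compound 2 `CCCCC/C=C\C/C=C\C/C=C\C/C=C\CCCC(=O)OC[C@@H]1C=CC(=O)[C@@H](C2CCCC=C2C)O1` gives 5000 nM, the highest number of the three, so compound 1 stands second highest. Among the measured compounds shown here, no two of these differ in one place only, so no single step is characterised. Compound 4 `O=C1C=C[C@@H](CC2=CCCCC2)O[C@@H]1CO` is not yet measured; it differs from compound 1 by hydrogen in place of acetyl on an oxygen on a saturated carbon. For the measured compounds named here, no measured pair shows what loss of the acyl group does, so the step from compound 1 to compound 4 is estimated as a moderate rise in number, a 2.3-fold higher number from compound 1 to compound 4 (0.37 log units; beyond the scatter). Compound 4 is expected to give about 350 nM in this assay, within 100 nM to 1500 nM.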

Compound 4, half-maximal inhibitory concentration: 3000 nM
Estimate against measurement, compound 4: 8.6-fold (0.93 log units) below, and the stated range ends below it.
By their numbers in this assay, from the lowest: compound 3; then compound 1; then compounds 4 and 2 (each within the scatter of the next).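

Among the compounds shown here, replacing acetoxymethyl with hydroxymethyl is the first single change that can be read: this assay shows a 20-fold higher number from compound 1 to compound 4 (1.30 log units; beyond the scatter) as a large step. On the shared core, the number therefore depends strongly on the acetyl on this oxygen on a saturated carbon, which the earlier esters, differing in more than one place, could not show. No measurement here explains the size of this step.

Open, on these data alone, is how a methyl ether, an amine or a longer acyl chain at this place would compare with acetyl and hydrogen. Also open, as far as these compounds go, is whether removing the acyl group has a similar effect with the side group of compound 3.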